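The source may report more compounds than this note shows. Statements on the series, on what has been measured and on what is new or still open speak of the compounds shown alone.

In an assay on isolated protein for inhibition of Rho-associated protein kinase 1 (Homo sapiens), read by scintillation counting, radiometric assay and 33P incorporation, with a stated time of 40 min, in the presence of a further agent that is not named here (a lower number here means a stronger inhibitor, a higher number a weaker inhibitor), compound 1 `CN(C)c1ccc(C(=O)Nc2cccc(NC(=O)COc3ccc4c(c3)CCC(=O)N4)c2)cc1` gives only a limit, > 10000 nM. This value sits at the limit of > 10000 nM in this assay, at which 1 of the 3 values shown sits. Within the data shown here, compound 2 `CN(C)c1ccc(C(=O)Nc2cccc(NC(=O)COc3ccc4c(c3)OCCC4=O)c2)cc1` gives 144 nM, and the step of an at least 69-fold lower number from compound 1 to compound 2 (1.84 log units; beyond the scatter) is the only change measured at a single place, on an oxygen on a saturated carbon. Compound 3 `Cc1ccc(C(=O)Nc2cccc(NC(=O)COc3ccc4c(=O)ccoc4c3)c2)cc1` gives 183 nM, the highest of the two numbers, with compound 2 lying within the scatter of it. Compound 4 `Cc1cc(C(=O)Nc2cccc(NC(=O)COc3ccc4c(=O)ccoc4c3)c2)ccc1C(F)(F)F` differs from compound 3 by a group of 11 heavy atoms (8 carbon, 3 fluorine; one six-membered aromatic ring of carbon only) in place of a group of 7 heavy atoms (7 carbon; one six-membered aromatic ring of carbon only), on a carbonyl carbon. Among the measured compounds shown here, no measured step touches the carbonyl carbon, so the one measured step offers no guide for this change, and a step no larger than the scatter is expected, a 1.4-fold higher number from compound 3 to compound 4 (0.14 log units; within the scatter). For compound 4 a value of 250 nM is estimated, between 80 nM and 800 nM.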

Compound 4, half-maximal inhibitory concentration: 460 nM
The estimate for compound 4 lay 1.8-fold (0.26 log units) below the measured number; the range from low to high includes it.
By their numbers in this assay, from the lowest: compounds 2 and 3 (each within the scatter of the next); then compound 4. At a limit, above all of these: compound 1.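

Among these compounds, this is the first measured change on the carbonyl carbon, and in this assay it gives a 2.5-fold higher number from compound 3 to compound 4 (0.40 log units; beyond the scatter), a modest step. Replacing 4-methylphenyl with the group of 11 heavy atoms that carries fluorine therefore moves the number at this place, yet compound 4 still gives a measured number and not a limit. Nothing shown here accounts for the size of this step. Still open, on these data alone, is how an amine or a carboxylic acid on this aromatic ring would read. Also open, as far as these compounds go, is whether the same change on the core of compound 2 would give a similar step.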